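A few compounds are considered here, and "the series" means these few. Any claim that something is new, unique, unknown or untested is made for them only; others in the source may bear on it.

Three compounds have been measured in an assay on isolated protein for inhibition of sulfide:quinone oxidoreductase, mitochondrial (Homo sapiens); a higher number here means a weaker inhibitor, a lower number a stronger inhibitor:

compound 1, `COc1cccc(-c2cc(-c3ccc(F)cc3)c(C#N)c(OC)n2)c1`, giving 108 nM;
compound 2, `COCCOc1nc(-c2ccccc2)cc(-c2ccc(F)cc2)c1C#N`, giving 123 nM;
compound 3, `N#Cc1c(-c2ccccc2)cc(-c2ccccc2)nc1OCc1ccccc1`, giving 100 nM.

Compound 1 holds the second highest of the three numbers, yet its nearest neighbour, compound 3, and its furthest, compound 2, both sit within the scatter of it, so the three cannot be told apart in this assay. Compound 4, `COc1nc(-c2ccccn2)cc(-c2ccc(F)cc2)c1C#N`, has not yet been measured. It differs from compound 1 in one place: pyridin-2-yl in place of 3-methoxyphenyl on an aromatic carbon. Within the data shown here, no measured pair shows this exchange, so the expectation rests on the three values being alike: compounds 2 and 3 lack the 3-methoxyphenyl group and still give numbers close to compound 1, which suggests that this part of the molecule tolerates change. For compound 4 the expected 1.9-fold higher number from compound 1 to compound 4 (0.27 log units; within the scatter) is therefore small and, if anything, toward a higher number, most likely inside the scatter. The estimate for compound 4 is 200 nM, with a range from 60 nM to 700 nM.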

Compound 4, half-maximal inhibitory concentration: 14 nM
Compound 4: middle estimate off by 14-fold (1.15 log units), on the high side, and the stated range ends above it.
By their numbers in this assay, from the lowest: compound 4; then compounds 3, 1 and 2 (each within the scatter of the next).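

In this assay, pyridin-2-yl in place of 3-methoxyphenyl on the aromatic carbon next to the ring nitrogen gives a 7.7-fold lower number from compound 1 to compound 4 (0.89 log units; beyond the scatter), showing that this position responds clearly to the group it carries. The three earlier compounds could not show this, as they gave alike values and no two of them differed in one place only. The exchange removes the methoxy group and brings in a ring nitrogen together, and nothing available explains the lower number.

The compounds shown leave open which of those two parts of the exchange accounts for the step, a question that an unsubstituted phenyl group on the core of compound 4 would address. They also leave open whether pyridin-3-yl, pyridin-4-yl or pyrimidin-2-yl at this carbon would give a similar number.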